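Swapping nitrile for chlorine: expected half-life of compound 3

A few compounds are considered here, and "the series" means these few. Any claim that something is new, unique, unknown or untested is made for them only; others in the source may bear on it.

Measured so far:
- compound 1, `CNC(=O)c1ccc(-c2cnc3cnc(C(=O)N(C)c4ccc(C#N)cc4)cn23)cc1`: 1.63 h
- compound 2, `CN(C(=O)c1cn2c(-c3ccc(-c4nnc(N)s4)cc3)cnc2cn1)c1ccc(C#N)cc1`: 3.39 h

Of the compounds shown here, two have been measured in an ADME assay on the whole organism for metabolic stability, with Mus musculus as the target, at a dose of 20 mg/kg by the oral route; a higher number here means that the compound lasts longer, a lower number that the compound disappears faster. Compound 1 gives 1.63 h, the lower of the two numbers. Compound 2 gives 3.39 h, and the step of a 2.1-fold higher number from compound 1 to compound 2 (0.32 log units; beyond the scatter) came from putting 5-amino-1,3,4-thiadiazol-2-yl in place of methylcarbamoyl on an aromatic carbon.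

Compound 3, `CNC(=O)c1ccc(-c2cnc3cnc(C(=O)N(C)c4ccc(Cl)cc4)cn23)cc1`, has not yet been measured. It differs from compound 1 in one place: chloro in place of cyano on an aromatic carbon. This change sits on the ring that carries the methyl-bearing amide nitrogen, a part of the molecule that stays the same between compound 1 and compound 2. For the measured compounds named here, the one measured step therefore does not bear on the present change; it tells nothing about replacing cyano with chloro. Nothing in these data points to a clear direction, so no step beyond the scatter is expected, and the estimated step is a 1.0-fold higher number from compound 1 to compound 3 (0.02 log units; within the scatter). Compound 3 is expected to give about 1.7 h in this assay, within a range from 0.8 h to 3.5 h.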

Compound 3, half-life: 3.63 h
Compound 3: the middle estimate sits 2.1-fold (0.33 log units) below what was measured, and the stated range ends below it.
By their numbers in this assay, from the lowest: compound 1; then compounds 2 and 3 (each within the scatter of the next).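

The ring carrying the (4-cyanophenyl)(methyl)amino group is not a silent part of the molecule: in this assay, chloro in place of cyano on an aromatic carbon, para to a large group, gives a 2.2-fold higher number from compound 1 to compound 3 (0.35 log units; beyond the scatter). For the compounds shown here, the earlier step touched only the other end of compound 1, so this is the first sign that this second place can also shift the half-life beyond the scatter, although the finding rests on a single step at each place. Nothing measured here accounts for the change, so it stands as an observation without an explanation.

The compounds shown hold only cyano and chloro at this position, so it remains open how fluoro, methyl, methoxy or a plain hydrogen would compare there, and whether the step depends on chloro itself or simply on the loss of cyano. As far as these compounds go, it also remains open whether the two changes would add up in a single molecule, one with chloro on this ring together with the 5-amino-1,3,4-thiadiazol-2-yl group in place of methylcarbamoyl.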